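Removing a piperidinylmethyl arm from a benzophenone series

The source may hold more compounds than are shown below. What is called first, only, known or untested is meant among the compounds shown, and "the series" means these compounds.

Measured compounds:
compound 1 `COc1cc(O)c(C(=O)c2cccc(F)c2)c(OC)c1`, 81%
compound 2 `COc1cc(OC)c(C(=O)c2cccc(Cl)c2)c(O)c1CN1CCCCC1`, 83%
compound 3 `COc1cc(O)c(C(=O)c2ccccc2Br)c(OC)c1`, 72%

Of the compounds shown here, three have been tested in a functional assay on THP-1 cells (Homo sapiens) for inhibition, read by ELISA, with stated times of 30 min and 24 h, tested at 10 uM; on this read-out lower numbers stand for a weaker effect and higher numbers for a stronger effect at the one concentration tested. Compound 2 holds the highest of the three numbers, with 83%. Compound 1 is its nearest neighbour: in this assay compound 1 gives 81%, a gap that lies within the scatter of repeated measurements, so no order between compound 1 and compound 2 can be read from these two numbers. Compound 3 stands furthest away, with 72% in this assay, a gap beyond the scatter.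

Compound 4 `COc1cc(O)c(C(=O)c2cccc(Cl)c2)c(OC)c1` has not yet been measured in this assay. It differs from compound 2 in one place: hydrogen in place of (piperidin-1-yl)methyl on an aromatic carbon. The two chlorine-bearing compounds thus differ only in whether the (piperidin-1-yl)methyl group is present.

Among the compounds with values here, no measured pair in this set shows the effect of this change on its own. Compound 1, which likewise carries hydrogen at this position and a halogen in the same part of the molecule, gives 81% in this assay, close to compound 2. On that basis the step of a number 3 percentage points lower from compound 2 to compound 4 (within the scatter) is expected to be small, in no particular direction, and not beyond the scatter. Compound 4 is therefore estimated at 80% in this assay, within a range from 68% to 90%.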

Compound 4, a percentage reported as activity, at one concentration (the size of the read-out at that concentration, not a potency): 78%
Estimate against measurement, compound 4: 2 percentage points above; low and high end bracket the measured number.
By their numbers in this assay, from the lowest: compounds 3, 4, 1 and 2 (each within the scatter of the next, the first and the last beyond it).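

In this assay, the exchange of the (piperidin-1-yl)methyl group for hydrogen on this aromatic carbon, ortho to a hydroxy group, now has a direct reading: a number 5 percentage points lower from compound 2 to compound 4 (within the scatter). At the one concentration tested, the whole group, with its six-membered non-aromatic ring and its nitrogen, can therefore be lost without a step beyond the scatter, and the same holds for the exchange of fluoro for chloro on the other aromatic part, with a number 3 percentage points lower from compound 1 to compound 4 (within the scatter). Nothing available here speaks to why either change leaves so small a step.

What the compounds shown leave open is whether this position tolerates groups other than hydrogen and (piperidin-1-yl)methyl, such as a morpholin-4-ylmethyl group, a dimethylaminomethyl group or a carboxylic acid, in the same way. Going by these compounds, because the read-out gives the size of the effect at a single concentration and not a potency, it also remains open whether compound 2 and compound 4 would stay within the scatter of each other at lower concentrations.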